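Thiophene in place of hydroxyphenyl on a thiosemicarbazone

The source may hold more compounds than are shown below. What is called first, only, known or untested is meant among the compounds shown, and "the series" means these compounds.

Compound 1, `CC1=CC[C@H](C(C)(C)N=C=S)CC1`, in an ADME assay on Vero cells (Chlorocebus sabaeus) for inhibition, read by sulforhodamine B assay, with a stated time of 48 h (a higher number here means a weaker inhibitor of growth, a lower number a stronger inhibitor of growth), gives > 100000 nM, which is a limit of the assay and not a number.
Compound 2, `CC1=CC[C@H](C(C)(C)NC(=S)N/N=C/c2ccccc2O)CC1`, in this assay gives 3100 nM.
Compound 3, `CC1=CC[C@H](C(C)(C)NC(=S)N/N=C/c2ccccc2[N+](=O)[O-])CC1`, in this assay gives 21600 nM.

Compound 2 holds the lowest of the two numbers in this assay. Its nearest neighbour is compound 3, reached by nitro in place of hydroxy on an aromatic carbon, and that step is a 7.0-fold higher number from compound 2 to compound 3 (0.84 log units; beyond the scatter). Compound 1, the isothiocyanate that shares the core, sits at the limit of > 100000 nM in this assay, at which 1 of the 3 values shown sits.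

Compound 4, `CC1=CC[C@H](C(C)(C)NC(=S)N/N=C/c2cccs2)CC1`, has not yet been measured. It differs from compound 2 by thiophen-2-yl in place of 2-hydroxyphenyl on a carbon with a double bond to nitrogen. Going by the values given here, the one measured step that bears on this change is a 7.0-fold higher number from compound 2 to compound 3 (0.84 log units; beyond the scatter), which also removed the hydroxy and was modest, beyond the scatter, towards a weaker inhibitor of growth. On the strength of a 7.0-fold higher number from compound 2 to compound 3 (0.84 log units; beyond the scatter), a step in the same direction but of smaller size is expected for compound 4, namely a 2.6-fold higher number from compound 2 to compound 4 (0.41 log units; beyond the scatter). The estimate for compound 4 in this assay is 8000 nM, with a range from 2500 nM to 25000 nM.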

Compound 4, concentration for 50% growth inhibition: 10100 nM
The estimate for compound 4 lay 1.3-fold (0.10 log units) below the measured number, and the stated range covers the measured number.
By their numbers in this assay, from the lowest: compound 2; then compound 4; then compound 3. At a limit, above all of these: compound 1.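

With the whole ring exchanged at the carbon with a double bond to nitrogen, and not just the group it carries, the change from 2-hydroxyphenyl to thiophen-2-yl gives a 3.3-fold higher number from compound 2 to compound 4 (0.51 log units; beyond the scatter) in this assay. This means that the higher number seen earlier, a 7.0-fold higher number from compound 2 to compound 3 (0.84 log units; beyond the scatter), is no longer a single case tied to nitro: both compounds without the hydroxy group, one keeping a six-membered aromatic ring and one carrying a five-membered ring with sulfur, stand on the weaker side of compound 2, and none of the compounds with a measured number goes against this. Nothing measured here accounts for the size of the step to thiophen-2-yl.

The compounds shown leave open whether the loss of the hydroxy group alone produces these steps, since an unsubstituted phenyl, or a methoxy or an amine in place of the hydroxy on the same ring, would separate that loss from the other changes. From the compounds shown here alone, it also remains open how a thiophene carrying its own hydroxy group, or a furan with oxygen in place of the ring sulfur, would read in this assay.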